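From 2,5-dimethylphenyl to 2-fluorophenyl

This account rests on a few compounds, and the source may have more. Where it says the series, first, only, none or still open, it means among the compounds named here.

Measured in a functional assay on DU-145 cells (Homo sapiens) for inhibition, read by trypan blue exclusion, with a stated time of 96 h; on this read-out lower numbers stand for stronger inhibition of growth and higher numbers for weaker inhibition of growth:
- compound 1 `O=C(/C(=C\c1ccc(Cl)cc1Cl)S(=O)(=O)c1ccc(Br)cc1)c1ccc(Cl)cc1`: 50000 nM
- compound 2 `COc1cc(/C=C(/SCc2ccc(Br)cc2)C(=O)c2ccc(C(=O)O)cc2)ccc1F`: 1000 nM
- compound 3 `Cc1ccc(C)c(/C=C(\C(=O)c2ccc(Cl)cc2)S(=O)(=O)c2ccc(Br)cc2)c1`: 1000 nM

Compound 3 shows the same number as compound 2, and both numbers sit far under that of compound 1. Compound 4 `O=C(/C(=C\c1ccccc1F)S(=O)(=O)c1ccc(Br)cc1)c1ccc(Cl)cc1` keeps the core of compound 3 but carries 2-fluorophenyl in place of 2,5-dimethylphenyl on a double-bonded chain carbon bound to a double-bonded chain carbon. Among the measured compounds shown here, one measured step bears on this place, and it is large: a 50-fold lower number from compound 1 to compound 3 (1.70 log units; beyond the scatter). For the measured compounds named here, no measured compound carries 2-fluorophenyl, so the size of the new step remains uncertain. Compound 1 and compound 3 mark the span seen so far, and a moderate move towards weaker inhibition of growth is expected. The expected step is a 5.0-fold higher number from compound 3 to compound 4 (0.70 log units; beyond the scatter). Compound 4 is estimated at 5000 nM, with an expected range from 800 nM to 40000 nM.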

Compound 4, concentration for 50% growth inhibition: 25000 nM
Compound 4: the middle estimate sits 5.0-fold (0.70 log units) below what was measured, and the stated range covers the measured number.
By their numbers in this assay, from the lowest: compounds 2 and 3 (each within the scatter of the next); then compounds 4 and 1 (each within the scatter of the next).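

In this assay, the place on a double-bonded chain carbon bound to a double-bonded chain carbon proves sensitive on a second change: with 2-fluorophenyl there is a 25-fold higher number from compound 3 to compound 4 (1.40 log units; beyond the scatter), which gives back nearly all of the earlier gain. Set against 2,4-dichlorophenyl, 2-fluorophenyl shows a 2.0-fold lower number from compound 1 to compound 4 (0.30 log units; within the scatter), so these two halogen-bearing groups stand together and 2,5-dimethylphenyl alone stands apart. No measurement at hand explains this difference.

Whether both methyl groups are needed remains open, since 2-methylphenyl and 3-methylphenyl are not among the compounds shown. As far as these compounds go, how an amine on this phenyl ring would compare also remains open.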